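This account rests on a few compounds, and the source may have more. Where it says the series, first, only, none or still open, it means among the compounds named here.

Among the measured compounds shown here, in an ADME assay for permeability, using PAMPA, with a stated time of 4 h (on this read-out lower numbers stand for lower permeability and higher numbers for higher permeability), compound 3 `Cc1ccnc(Oc2ccc3nc(COc4cccc(C(=O)O)c4)n(C)c3c2)c1` gives 3.5 10^-6 cm/s, the lowest of the three numbers measured so far. Compound 1 `Cn1c(COc2cccc(C(=O)O)c2)nc2ccc(Oc3ccc(Cl)c(F)c3)nc21` gives 25.6 10^-6 cm/s and compound 2 `Cc1cc(C)cc(Oc2ccc3nc(COc4cccc(C(=O)O)c4)n(C)c3n2)c1` gives 17.4 10^-6 cm/s, both beyond the scatter above compound 3. Compound 4 `Cn1c(COc2cccc(C(=O)O)c2)nc2ccc(Oc3ncc(Cl)cc3F)cc21` differs from compound 3 in one place: 5-chloro-3-fluoropyridin-2-yl in place of 4-methylpyridin-2-yl on an oxygen on an aromatic ring. For the measured compounds named here, the only measured step that resembles this swap of the aryl group on the ether oxygen is the one from compound 1 to compound 2, where a 1.5-fold lower number from compound 1 to compound 2 (0.17 log units; within the scatter). That step suggests that exchanging the aryl group on this oxygen moves the number little, so the expected step from compound 3 to compound 4 is a 1.3-fold higher number from compound 3 to compound 4 (0.11 log units; within the scatter), a change that is not expected to exceed the scatter. Compound 4 is therefore estimated at 4.5 10^-6 cm/s, with a range from 2 10^-6 cm/s to 10 10^-6 cm/s.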

Compound 4, apparent permeability: 11.8 10^-6 cm/s
Beside the measured number, compound 4's estimate is 2.6-fold (0.42 log units) below it, outside the stated range (above it).
By their numbers in this assay, from the lowest: compound 3; then compounds 4, 2 and 1 (each within the scatter of the next, the first and the last beyond it).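

In this assay, the group on this oxygen can shift the number clearly: 5-chloro-3-fluoropyridin-2-yl in place of 4-methylpyridin-2-yl gives a 3.4-fold higher number from compound 3 to compound 4 (0.53 log units; beyond the scatter) on this core. The earlier aryl swap on an oxygen, on a different core, gave only a 1.5-fold lower number from compound 1 to compound 2 (0.17 log units; within the scatter) and so did not show a change of this size. No measurement at hand explains the step.

On these data alone, the chlorine and the fluorine enter together, so the share of each remains open. Also open, as far as these compounds go, is how a longer alkyl chain on this oxygen would read.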